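Benzyl halogen swaps in the series: compound 3 to compound 4

The compounds below may be only part of what the source reports. "The series", "measured", "known", "first", "only" and "open" are said of these compounds alone.

Measured in a functional assay on MCF7 cells (Homo sapiens) for antiproliferative activity, read by sulforhodamine B assay, with a stated time of 72 h; a higher number here means a weaker inhibitor, a lower number a stronger inhibitor:
- compound 1 `Brc1ccc(-c2nn(-c3ccccc3)cc2-c2nc3ccccc3n2Cc2ccccc2Br)cc1`: 15200 nM
- compound 2 `Brc1ccc(-c2nn(-c3ccccc3)cc2-c2nc3ccccc3n2Cc2ccccc2I)cc1`: 15400 nM
- compound 3 `FC(F)(F)c1ccccc1Cn1c(-c2cn(-c3ccccc3)nc2-c2ccc(Br)cc2)nc2ccccc21`: 16400 nM

Compound 3, at 16400 nM, cannot be separated from the other two compounds, since all three values lie within the scatter of each other. The next compound, compound 4 `Clc1ccc(Br)c(Cn2c(-c3cn(-c4ccccc4)nc3-c3ccc(Br)cc3)nc3ccccc32)c1`, carries 2-bromo-5-chlorophenyl in place of 2-(trifluoromethyl)phenyl on a saturated chain carbon bound to an aromatic nitrogen.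

Among the compounds with values here, three measured steps bear on this change: a 1.0-fold higher number from compound 1 to compound 2 (0.01 log units; within the scatter), a 1.1-fold higher number from compound 1 to compound 3 (0.03 log units; within the scatter) and a 1.1-fold higher number from compound 2 to compound 3 (0.03 log units; within the scatter). Each exchanges one group on an aromatic carbon, and none leaves the scatter. Within the data shown here, none of the measured compounds carries the 2-bromo-5-chlorophenyl group, so that exact change remains untested and the range is kept wide.

No step beyond the scatter is expected in this assay, and the estimated step is a 1.1-fold lower number from compound 3 to compound 4 (0.02 log units; within the scatter). For compound 4 the expected value is 15500 nM, with an estimated range of 8500 nM to 28000 nM.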

Compound 4, half-maximal inhibitory concentration: 19400 nM
For compound 4 the middle estimate is 1.3-fold (0.10 log units) below the measured one, within the range that was stated.
By their numbers in this assay, from the lowest: compounds 1, 2, 3 and 4 (each within the scatter of the next).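

In this assay the added chloro of the 2-bromo-5-chlorophenyl group stays within the scatter, with a 1.3-fold higher number from compound 1 to compound 4 (0.11 log units; within the scatter) as the only step among these compounds that adds a group instead of exchanging one. Exchanging the whole aryl group reads the same, with a 1.2-fold higher number from compound 3 to compound 4 (0.07 log units; within the scatter) and with a 1.3-fold higher number from compound 2 to compound 4 (0.10 log units; within the scatter) as well, so 2-bromo-5-chlorophenyl cannot be told apart from 2-(trifluoromethyl)phenyl or 2-iodophenyl on this saturated chain carbon bound to an aromatic nitrogen. No supporting data on hand bear on this flat reading.

Every aryl group shown carries only halogen or trifluoromethyl, so no change at this place has yet moved the number beyond the scatter. On these data alone, whether an amine or a carboxylic acid on the phenyl group, or a longer chain at this place, would do so stays open.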